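The source may report more compounds than this note shows. Statements on the series, on what has been measured and on what is new or still open speak of the compounds shown alone.

Compound 2 `Cc1cccn2c(/C=N/O)c(-c3ccc(F)cc3)nc12` was tested in a functional assay on the whole organism (strain NMRI) with Mus musculus as the target, with a stated time of 4 h (a lower number here means that less compound is needed, a higher number that more compound is needed for the effect), where compound 2 gives 40 mg/kg. Compound 1 `C#CCO/N=C/c1c(-c2ccc(C)cc2)nc2c(C)cccn12` gives 20 mg/kg in this assay, and the two values lie within the usual scatter of each other, so they cannot be set apart. Compound 3 `Cc1ccc(-c2nc3c(C)cccn3c2/C=N/O)cc1` has not yet been measured. It differs from compound 2 by methyl in place of fluoro on an aromatic carbon. Compound 1 also bears a methyl, and its value of 20 mg/kg gives no sign of a change beyond the scatter. The step of a 1.3-fold lower number from compound 2 to compound 3 (0.12 log units; within the scatter) is therefore expected to be small, at most slightly downward. Compound 3 is estimated at 30 mg/kg, with a range from 10 mg/kg to 80 mg/kg.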

Compound 3, minimum effective dose: 40 mg/kg
Estimate against measurement, compound 3: 1.3-fold (0.12 log units) below; low and high end bracket the measured number.
By their numbers in this assay, from the lowest: compounds 1, 2 and 3 (each within the scatter of the next).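

In this assay, methyl in place of fluoro on an aromatic carbon, para to a large group, shows no change at the digits printed from compound 2 to compound 3 (within the scatter), so the two groups cannot be told apart at this position. Hydrogen in place of propargyl on an oxygen gives a 2.0-fold higher number from compound 1 to compound 3 (0.30 log units; within the scatter), so the propargyl group cannot be set apart from hydrogen either. As far as these compounds go, whether an amine or a carboxylic acid at the aromatic position, or a longer chain on the oxygen, would move the number beyond the scatter remains open. Nothing available explains these values.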